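Cytotoxicity notes: ethoxy for fluoro on the amide aryl

The source may hold more compounds than are shown below. What is called first, only, known or untested is meant among the compounds shown, and "the series" means these compounds.

Three analogues sharing one core have been profiled in an ADME assay on NCM460 cells (Homo sapiens) for cytotoxicity, read by MTT assay, with a stated time of 72 h; on this read-out higher numbers stand for weaker inhibition and lower numbers for stronger inhibition. Compound 1 `Cc1cccc(NC(=O)c2cccc(/C=C3\CC(=O)N(c4ccccc4)C3=O)c2)c1` reports only the assay limit in this assay, > 100000 nM. Compound 2 `O=C(Nc1ccc(OC(F)F)cc1)c1cccc(/C=C2\CC(=O)N(c3ccccc3)C2=O)c1` likewise sits at the limit in this assay, > 100000 nM. Compound 3 `O=C(Nc1ccc(F)cc1)c1cccc(/C=C2\CC(=O)N(c3ccccc3)C2=O)c1` also returns the limit in this assay, > 100000 nM. The steps a step that the two limits leave unreadable from compound 1 to compound 2, a step that the two limits leave unreadable from compound 1 to compound 3 and a step that the two limits leave unreadable from compound 2 to compound 3 have no readable size, since all three values sit at the limit of > 100000 nM in this assay, at which 3 of the 3 values shown sit. Compound 3 thus stands at the limit alongside the others, and no order among them can be read.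

The next compound, compound 4 `CCOc1ccc(NC(=O)c2cccc(/C=C3\CC(=O)N(c4ccccc4)C3=O)c2)cc1`, differs from compound 3 by ethoxy in place of fluoro on an aromatic carbon. Among the compounds with values here, no measured step with a readable size bears on this change; each earlier exchange of the aryl group on the amide-type nitrogen left the value at the limit of > 100000 nM in this assay, at which 3 of the 3 values shown sit. The expected step in this assay is a step that the limit leaves unreadable from compound 3 to compound 4, nothing beyond the scatter. Compound 4 is estimated at 150000 nM, between 50000 nM and 500000 nM, most likely again reported as a limit.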

Compound 4, half-maximal inhibitory concentration: > 100000 nM
Compound 4: a limit, no number; the forecaster's own chance of this, stated with the estimate: 85%; the middle value is on the limit's open side.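

In this assay compound 4 gives only a limit, > 100000 nM. Its steps from compound 1, compound 2 and compound 3 cannot be read: the limit of > 100000 nM in this assay, at which 4 of the 4 values shown sit.

The compounds shown leave open whether any aryl group on the amide-type nitrogen shifts the value, and no order among the four can be read.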